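Moving the Hydroxyl Group Sharply Changes Topoisomerase Inhibition

The source may report more compounds than this note shows. Statements on the series, on what has been measured and on what is new or still open speak of the compounds shown alone.

Compound 2 `Oc1ccc(-c2cc(-c3ccccc3)nc(-c3ccc(Cl)cc3)c2)cc1` carries a 4-hydroxyphenyl group and a 4-chlorophenyl group on the shared core. In an assay on isolated protein for inhibition of DNA topoisomerase 1 (Homo sapiens), with a stated time of 30 min, tested at 100 uM (a lower number here means a weaker effect, a higher number a stronger effect of the compound at the concentration tested), compound 2 gives 68%. Compound 1 `Oc1cccc(-c2cc(-c3ccccc3)nc(-c3ccc(Cl)cc3)c2)c1` differs from it only by 3-hydroxyphenyl in place of 4-hydroxyphenyl on an aromatic carbon. In this assay compound 1 gives 7.1%, a large step of a number 60.9 percentage points lower from compound 2 to compound 1 (beyond the scatter). Compound 3 `Oc1ccc(-c2cc(-c3ccccc3)nc(-c3cccc(Cl)c3)c2)cc1` differs from compound 2 by 3-chlorophenyl in place of 4-chlorophenyl on an aromatic carbon, and in this assay compound 3 gives 0%, a step of a number 68 percentage points lower from compound 2 to compound 3 (beyond the scatter). Compound 3 and compound 1 lie within the usual scatter of each other, so no order between them can be read.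

Compound 4 `Oc1cccc(-c2cc(-c3ccccc3)nc(-c3cccc(Cl)c3)c2)c1` has not yet been measured. It differs from compound 3 by 3-hydroxyphenyl in place of 4-hydroxyphenyl on an aromatic carbon. This is the same kind of change as that from compound 2 to compound 1, but not the same: in compound 2 the place is meta to a 4-chlorophenyl group, in compound 3 it is meta to a 3-chlorophenyl group, and the two cores differ exactly as compound 3 differs from compound 2. The earlier step was large and downward. Here, however, compound 3 already gives 0%, so a drop of similar size is not possible, and the step is expected to be small, about a number 3 percentage points higher from compound 3 to compound 4 (within the scatter). Because compound 1 gives 7.1% after the same kind of change, compound 4 is estimated at 3%, expected between 0% and 12% in this assay.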

Compound 4, a percentage reported as inhibition, at one concentration (the size of the read-out at that concentration, not a potency): 11.5%
For compound 4 the middle estimate is 8.5 percentage points below the measured one; low and high end bracket the measured number.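

Swapping 4-hydroxyphenyl for 3-hydroxyphenyl does not have the same result on the two cores, as the core of compound 3 gives a number 11.5 percentage points higher from compound 3 to compound 4 (beyond the scatter), in contrast with the large drop seen on the core of compound 2: the same change on two cores in this assay, a number 60.9 percentage points lower (beyond the scatter) from compound 2 to compound 1 and a number 11.5 percentage points higher (beyond the scatter) from compound 3 to compound 4, 72.4 percentage points apart, beyond the scatter of two such steps. Swapping 4-chlorophenyl for 3-chlorophenyl likewise depends on the core, since the core of compound 1 gives a number 4.4 percentage points higher from compound 1 to compound 4 (within the scatter), whereas the same swap on compound 2 removed the whole read-out: the same change on two cores in this assay, a number 68 percentage points lower (beyond the scatter) from compound 2 to compound 3 and a number 4.4 percentage points higher (within the scatter) from compound 1 to compound 4, 72.4 percentage points apart, beyond the scatter of two such steps. In this assay, this shows that neither swap can be carried from one core to the other as a fixed step among these four compounds, but it rests on only two cores for each swap, gives no potency, and does not show why the steps differ.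

As far as these compounds go, it remains open whether the value of compound 2, 68%, depends on the hydroxyl and the chlorine themselves, since an amine or a methoxy group in place of the hydroxyl, or a fluorine or a bromine in place of the chlorine, would test this. The compounds shown also leave open how a carboxylic acid or a longer chain on the phenyl group of the shared core would behave.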